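This account rests on a few compounds, and the source may have more. Where it says the series, first, only, none or still open, it means among the compounds named here.

Working notes on the aryl sulfamate series.

The read-out throughout is an assay on HEK293 cells for inhibition of Steryl-sulfatase (Homo sapiens), tested at 1 uM; on this read-out higher numbers stand for a stronger effect at the one concentration tested and lower numbers for a weaker effect. Three compounds have numbers. Compound 1 `CCN(Cc1ccc(Br)cc1)c1ccc(C(=O)N2CCc3ccc(OS(N)(=O)=O)cc3C2)cc1` gives 95.9% in this assay. Compound 2 `CCN(Cc1ccccc1)Cc1ccc(S(=O)(=O)N2CCc3ccc(OS(N)(=O)=O)cc3C2)cc1` gives 31%, and compound 3 `CN(CCCN1CCCCC1)c1cccc(C(=O)N2CCc3ccc(OS(N)(=O)=O)cc3C2)c1` gives 30.6%. Compound 1 therefore stands highest of the three; its nearest neighbour is compound 2, a number lower by an amount beyond the usual scatter, and compound 3 lies lower still, also beyond the scatter. Compounds 2 and 3 sit within the scatter of each other, so nothing is said about their order. Going by the values given here, no pair of measured compounds differs in a single place, so no single-site step has been quantified.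

The next compound, compound 4 `CCCN(Cc1ccccc1)c1ccc(C(=O)N2CCc3ccc(OS(N)(=O)=O)cc3C2)cc1`, keeps the shared core of compound 1 and its amide linkage, and changes only one substituent: benzyl(propyl)amino in place of (4-bromobenzyl)(ethyl)amino on an aromatic carbon. The change leaves the amide and the carbocyclic aromatic ring in place and exchanges the amino substituent on that ring. Given that compound 1 gives 95.9%, compound 4 is expected to stay in the high range; the step of a number 10.9 percentage points lower from compound 1 to compound 4 (beyond the scatter) is expected to be small and downward, at most modestly beyond the scatter. Compound 4 is accordingly estimated at 85%, with a range from 55% to 98%.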

Compound 4, a percentage reported as inhibition, at one concentration (the size of the read-out at that concentration, not a potency): 94.3%
Estimate against measurement, compound 4: 9.3 percentage points below; low and high end bracket the measured number.
By their numbers in this assay, from the lowest: compounds 3 and 2 (each within the scatter of the next); then compounds 4 and 1 (each within the scatter of the next).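

In this assay, benzyl(propyl)amino in place of (4-bromobenzyl)(ethyl)amino on an aromatic carbon, para to a large group, gives a number 1.6 percentage points lower from compound 1 to compound 4 (within the scatter), the first single-site step quantified in the series. At this position, then, a substituent without bromine and with a propyl chain in place of the ethyl chain reads the same as the original within the scatter, so the bromine is not required for a high read-out when the propyl chain is present. No measured evidence on the cause of this outcome is available.

Going by these compounds alone, the single step alters the benzyl ring and the alkyl chain together, so the separate contribution of each stays unresolved, and a read-out at one concentration does not show whether the potencies of the two compounds differ. Also open, as far as these compounds go, is how this position responds to more distant replacements, such as a carboxylic acid on the benzyl ring or a butyl chain on the amino nitrogen.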